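The source may hold more compounds than are shown below. What is called first, only, known or untested is meant among the compounds shown, and "the series" means these compounds.

Compound 1 `Cn1cc(-c2nc3ccccc3n2C(=O)c2ccccc2)c2ccccc21`: 19600 nM
Compound 2 `COc1ccc2c(c1)c(-c1nc3ccccc3n1C(=O)c1ccccc1)cn2C`: 16700 nM

In a functional assay on A549 cells (Homo sapiens) for inhibition, read by MTT assay, with a stated time of 24 h (a higher number here means a weaker inhibitor of growth, a lower number a stronger inhibitor of growth), compound 2 gives 16700 nM, which stands level with compound 1 within the scatter. Compound 3 `Cn1cc(-c2nc3ccccc3n2C(=O)c2ccccc2)c2cc(Br)ccc21` differs from compound 2 by bromo in place of methoxy on an aromatic carbon. Among the measured compounds shown here, the only measured step is a 1.2-fold lower number from compound 1 to compound 2 (0.07 log units; within the scatter), for methoxy in place of hydrogen on an aromatic carbon. For the measured compounds named here, no measured step involves bromo, and the one available step is small, so no change beyond the scatter is expected in this assay. The expected change is a 1.2-fold lower number from compound 2 to compound 3 (0.08 log units; within the scatter). Compound 3 is estimated at 14000 nM, with an expected range of 6000 nM to 30000 nM.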

Compound 3, concentration for 50% growth inhibition: 23100 nM
Compound 3: the middle estimate sits 1.7-fold (0.22 log units) below what was measured, within the range that was stated.
By their numbers in this assay, from the lowest: compounds 2, 1 and 3 (each within the scatter of the next).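

In this assay the step of a 1.4-fold higher number from compound 2 to compound 3 (0.14 log units; within the scatter) and the step of a 1.2-fold higher number from compound 1 to compound 3 (0.07 log units; within the scatter) both stay small, so hydrogen, methoxy and bromo on this aromatic carbon are not told apart by this read-out. The earlier pair showed this for methoxy alone, and compound 3 extends it to bromo, a single heavy atom. No measurement shown here offers a reason for this flat result. Going by these compounds, whether an amine or a carboxylic acid on this same carbon would move the number beyond the scatter stays open, as does whether changes elsewhere on the shared core would do so.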